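This account rests on a few compounds, and the source may have more. Where it says the series, first, only, none or still open, it means among the compounds named here.

In a functional assay on PC-3 cells (Homo sapiens) for antiproliferative activity, read by MTT assay, with a stated time of 72 h (a higher number here means a weaker inhibitor, a lower number a stronger inhibitor), compound 1 (`O=C(N/N=C/c1cccc(Cl)c1Cl)Nc1ccc(Oc2ccnc3[nH]ccc23)c(F)c1`) is reported as "not active" (no number reported) and has no number. Among the measured compounds shown here, compound 2 (`O=C(N/N=C/c1ccc(F)cc1Cl)Nc1ccc(Oc2ccnc3[nH]ccc23)c(F)c1`) gives 3 nM as the only number so far, so it cannot yet be ranked against another value. Compound 3 (`O=C(N/N=C/c1ccc(O)c(Br)c1)Nc1ccc(Oc2ccnc3[nH]ccc23)c(F)c1`) has 3-bromo-4-hydroxyphenyl in place of 2-chloro-4-fluorophenyl on a carbon with a double bond to nitrogen. With compound 2 at 3 nM and compound 1 without a number, a weakening beyond the scatter is expected in this assay. The estimated step runs a 13-fold higher number from compound 2 to compound 3 (1.12 log units; beyond the scatter) in that direction. The estimated value for compound 3 is 40 nM (expected range 3 nM to 500 nM).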

Compound 3, half-maximal inhibitory concentration: 28600 nM
For compound 3 the middle estimate is 720-fold (2.85 log units) below the measured one, and the stated range ends below it.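

In this assay the change to 3-bromo-4-hydroxyphenyl from 2-chloro-4-fluorophenyl gives a 9500-fold higher number from compound 2 to compound 3 (3.98 log units; beyond the scatter) on the carbon with a double bond to nitrogen, so this position separates sharply between two groups of 8 heavy atoms each. The entering group brings 1 hydrogen-bond donor and 1 hydrogen-bond acceptor, and the leaving group brings neither. The compounds shown leave open whether the hydroxyl, the bromine or the loss of chlorine and fluorine carries the step, and how an amine or a carboxylic acid on this ring would read. No measurement at hand gives a cause for this step.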